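This account rests on a few compounds, and the source may have more. Where it says the series, first, only, none or still open, it means among the compounds named here.

Measured so far:
Compound 1, `CC(C)(Oc1ccc(NCc2cccc(Oc3ccccc3)c2)cc1)C(=O)O`, in a functional assay on CHO cells for agonist activity at Free fatty acid receptor 1 (Homo sapiens), read by a luciferase reporter (a lower number here means a smaller maximal response, a higher number a larger maximal response), gives 14%.
Compound 2, `NC(=O)CCc1ccc(NCc2cccc(Oc3ccccc3)c2)cc1`, in this assay gives 68%.

Among the compounds with values here, of these two, compound 2 stands higher: the only measured step, a number 54 percentage points higher from compound 1 to compound 2 (beyond the scatter), separates it from compound 1, and that gap lies beyond the usual scatter. Compound 3, `CNC(=O)CCc1ccc(NCc2cccc(Oc3ccccc3)c2)cc1`, has not yet been measured in this assay. It differs from compound 2 in one place: methyl in place of hydrogen on an amide-type nitrogen.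

Within the data shown here, the one measured step changed the whole side group on the aromatic carbon; it did not touch the amide-type nitrogen, so no measured step speaks directly to this change. Among the measured compounds shown here, with nothing to go on but the shared core and the size of the single step, compound 3 is expected to give about the same response as compound 2, with a step of a number 6 percentage points lower from compound 2 to compound 3 (within the scatter) that would sit within the scatter. The estimate for compound 3 is 62%, with a range from 35% to 85%.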

Compound 3, largest response reached (reported as percent of maximum), in percent of the reference or control that the assay uses: 67%
Compound 3: middle estimate off by 5 percentage points, on the low side; measured number inside the range.
By their numbers in this assay, from the lowest: compound 1; then compounds 3 and 2 (each within the scatter of the next).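

In this assay, methyl in place of the amide hydrogen gives a number 1 percentage points lower from compound 2 to compound 3 (within the scatter) and so leaves the response within the scatter, which shows that this nitrogen accepts a methyl group without a measurable change. Setting 2-(methylcarbamoyl)ethyl in place of 1-carboxy-1-methylethoxy on the aromatic carbon gives a number 53 percentage points higher from compound 1 to compound 3 (beyond the scatter) and so matches the large rise seen with the unmethylated amide, which means that this rise does not depend on the amide hydrogen. Nothing available explains why either result came out as it did.

From the compounds shown here alone, only methyl has been compared with hydrogen on this nitrogen, so it remains open whether a larger group such as ethyl or cyclopropyl, or a second methyl, would also leave the response in place. The same goes for the rest of the side group, where a carboxylic acid in place of the amide or a longer chain could behave differently.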